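The source may report more compounds than this note shows. Statements on the series, on what has been measured and on what is new or still open speak of the compounds shown alone.

For the measured compounds named here, compound 2, `Nc1scc(CN2CCN(c3ccc([N+](=O)[O-])cc3)CC2)c1C(=O)c1ccc(Cl)cc1`, is one of two compounds measured in a functional assay on CHO cells with adenosine receptor A1 (Homo sapiens) as the target, read by cAMP accumulation and immunoassay, with a stated time of 6 min, tested at 0.1 uM; a higher number here means a weaker effect of the compound at the concentration tested, a lower number a stronger effect. In this assay compound 2 gives -13%. Its nearest neighbour is compound 1, `Nc1scc(CN2CCN(c3ccc(Cl)cc3Cl)CC2)c1C(=O)c1ccc(Cl)cc1`, which in this assay gives -11%; the two numbers lie within the scatter of each other, so no order between them can be read. Going by the values given here, the one step that joins them, a number 2 percentage points lower from compound 1 to compound 2 (within the scatter), is a change of the aryl group on the amine nitrogen in the ring and left the read-out unchanged.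

Compound 3, `Nc1scc(CN2CCN(c3cccc(C(F)(F)F)c3)CC2)c1C(=O)c1ccc(Cl)cc1`, has not yet been measured. It differs from compound 2 in the same place: 3-(trifluoromethyl)phenyl in place of 4-nitrophenyl on an amine nitrogen in a ring. Among the compounds with values here, the only measured step that bears on this change is the step from compound 1 to compound 2, an exchange of one aryl group for another on that ring nitrogen, and it stayed within the scatter. On that basis no step beyond the scatter is expected in this assay, in either direction, so the step of a number 1 percentage points higher from compound 2 to compound 3 (within the scatter) is expected to be small. Compound 3 is therefore estimated to give -12% in this assay, with a range from -26% to 3%.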

Compound 3, a percentage reported as activity, at one concentration (the size of the read-out at that concentration, not a potency): -30%
For compound 3 the middle estimate is 18 percentage points above the measured one; measured number below the stated range.
By their numbers in this assay, from the lowest: compound 3; then compounds 2 and 1 (each within the scatter of the next).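

In this assay the aryl group on the amine nitrogen in the ring proves able to move the read-out: 3-(trifluoromethyl)phenyl in place of 4-nitrophenyl gives a number 17 percentage points lower from compound 2 to compound 3 (beyond the scatter), and the same group in place of 2,4-dichlorophenyl gives a number 19 percentage points lower from compound 1 to compound 3 (beyond the scatter). The earlier exchange of aryl groups at this position gave only a number 2 percentage points lower from compound 1 to compound 2 (within the scatter), so it had not shown that this position can respond; the two new steps show a stronger effect at the concentration tested, of modest size, with compound 3 beyond the scatter of both other compounds. No measurement is at hand that accounts for this step.

The compounds shown leave open whether the step belongs to the trifluoromethyl group itself or to where it sits on the phenyl ring, as 3-(trifluoromethyl)phenyl differs in both respects from the groups it replaces. Also open, from the compounds shown here alone, are how an unsubstituted phenyl, a methoxyphenyl or a benzyl group on that ring nitrogen would read, and how these compounds would read at other concentrations.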